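The source may report more compounds than this note shows. Statements on the series, on what has been measured and on what is new or still open speak of the compounds shown alone.

Compound 1, `Cc1nc2c(c(-c3cc(F)c4c(c3C)CCCO4)c1[C@H](OC(C)(C)C)C(=O)O)CN(CCCc1cccc(F)c1)CC2`, carries on the amine nitrogen of the shared core a 3-(3-fluorophenyl)propyl chain. In an ADME assay on MT2 cells (Homo sapiens) for cytotoxicity, read by XTT assay, with a stated time of 4 days (a higher number here means that more compound is tolerated, a lower number that less compound is tolerated), compound 1 gives only a limit of the measurement, > 40000 nM. Two relatives built on the same core behave in the same way. Compound 2, `Cc1ccc(-c2c3c(nc(C)c2C(OC(C)(C)C)C(=O)O)CCN(C)C3)cc1`, gives in this assay a limit as well, > 40000 nM. Compound 3, `Cc1ccc(-c2c3c(nc(C)c2[C@H](OC(C)(C)C)C(=O)O)CCN(C/C=C/c2ccccc2)C3)cc1`, likewise stops at a limit in this assay, > 40000 nM. Compound 1 therefore stands nowhere in particular among these numbers: every value shown is a limit, and the limit of > 40000 nM in this assay, at which 3 of the 3 values shown sit, leaves no room to rank compound 1 against compound 2 or compound 3.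

Compound 4, `Cc1nc2c(c(-c3cc(F)c4c(c3C)CCCO4)c1[C@H](OC(C)(C)C)C(=O)O)CN(CCCc1ccncc1)CC2`, differs from compound 1 in one place: pyridin-4-yl in place of 3-fluorophenyl on a saturated chain carbon, three bonds along the chain from an amine nitrogen in a ring. Within the data shown here, no step between two measured compounds of this set touches that part of the molecule, so any expectation rests on the three limits alone. Given (the limit of > 40000 nM in this assay, at which 3 of the 3 values shown sit), compound 4 is expected to show no shift beyond the scatter, a step that the limit leaves unreadable from compound 1 to compound 4. The value of compound 4 in this assay is accordingly estimated at 45000 nM, within a range from 20000 nM to 100000 nM, and most probably it will again be reported only as a limit.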

Compound 4, half-maximal cytotoxic concentration: > 40000 nM
Compound 4: no number, only a limit; the forecaster's own chance of this, stated with the estimate: 80%; the middle value is on the limit's open side.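

In this assay compound 4 gives only a limit, > 40000 nM, not a number. Among these compounds, compound 1 stands at a limit as well, so no step from compound 1 to compound 4 can be read. The compounds shown leave open whether pyridin-4-yl in place of 3-fluorophenyl changes the tolerated concentration at all, and where any of them would give a number: the limit of > 40000 nM in this assay, at which 4 of the 4 values shown sit.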